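The compounds below may be only part of what the source reports. "The series", "measured", "known", "first", "only" and "open" are said of these compounds alone.

Two compounds have been measured in a functional assay on L1210 cells (Mus musculus) for inhibition; on this read-out higher numbers stand for weaker inhibition and lower numbers for stronger inhibition:
compound 1, `Nc1nc2c(nc(Br)n2COCCO)c(=O)[nH]1`, with > 500 ug/mL
compound 2, `Nc1nc2c(nc(O)n2COCCO)c(=O)[nH]1`, with > 500 ug/mL

Neither reading is a number. For compound 1 the reading of > 500 ug/mL is a limit of the assay. For compound 2 the reading of > 500 ug/mL is likewise a limit, so compound 2 stands at the edge of what this assay can resolve, showing no measurable inhibition. Within the data shown here, the single measured step, a step that the two limits leave unreadable from compound 1 to compound 2, cannot be sized since both of its ends sit at the limit of > 500 ug/mL in this assay, at which 2 of the 2 values shown sit.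

Compound 3, `CNc1nc2c(=O)[nH]c(N)nc2n1COCCO`, differs from compound 2 by methylamino in place of hydroxy on an aromatic carbon. Among the measured compounds shown here, no measured step exchanges these two groups, and the only step available is unreadable, so no direction beyond the scatter can be foreseen. The expected step, a step that the limit leaves unreadable from compound 2 to compound 3, is therefore one of no clear size. Compound 3 is expected to give about 600 ug/mL in this assay, within 150 ug/mL to 2500 ug/mL, most likely again reported only as a limit.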

Compound 3, concentration for 50% inhibition: > 500 ug/mL
Compound 3: a limit, no number; the forecaster's own chance of this, stated with the estimate: 85%; the middle value lies beyond the limit too.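

Compound 3 also gives only a limit rather than a number, so no step among compound 1, compound 2 and compound 3 can be read: the limit of > 500 ug/mL in this assay, at which 3 of the 3 values shown sit.

The compounds shown leave open whether bromo, hydroxy or methylamino on this aromatic carbon makes any difference to inhibition.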